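The source may report more compounds than this note shows. Statements on the series, on what has been measured and on what is new or still open speak of the compounds shown alone.

Working notes on the series.

Compound 1 `CCCCN(c1nc2ccccc2o1)[C@H](C)c1ccc(-c2ccccc2-c2nnn[nH]2)cc1` is the reference point here. Going by the values given here, in an ADME assay on the whole organism (Macaca fascicularis) for pharmacokinetics, read by LC-MS, using cassette dosing, at a dose of 1 mg/kg by the oral route (on this read-out higher numbers stand for higher exposure at the dose given and lower numbers for lower exposure), compound 1 gives 29.2 nM, the lowest of the two numbers measured so far. Among the compounds with values here, the only other measured member, compound 2 `C[C@H](c1ccc(-c2ccccc2-c2nc(=O)o[nH]2)cc1)N(CC1CC1)c1nc2c(C(=O)O)cccc2o1`, gives 7710 nM in this assay, a gap well beyond the usual scatter; compound 2 differs from compound 1 in more than one place, so no single change can be read from that pair.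

The next compound, compound 3 `CCCCN(c1nc2c(C(=O)NC)cccc2o1)[C@H](C)c1ccc(-c2ccccc2-c2nnn[nH]2)cc1`, takes a single step from compound 1: methylcarbamoyl in place of hydrogen on an aromatic carbon. Compound 2 carries a different group at a comparable part of its core and sits far higher, but with its other differences that is only a pointer, not a measured step.

The expectation is that compound 3 moves upward from compound 1 in this assay by roughly a 5.1-fold higher number from compound 1 to compound 3 (0.71 log units; beyond the scatter), a step beyond the scatter but well short of the distance to compound 2. On that basis the maximal plasma concentration of compound 3 is estimated at 150 nM, with a range from 30 nM to 800 nM.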

Compound 3, maximal plasma concentration: 19.7 nM
For compound 3 the middle estimate is 7.6-fold (0.88 log units) above the measured one, and the stated range ends above it.
By their numbers in this assay, from the lowest: compounds 3 and 1 (each within the scatter of the next); then compound 2.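

Going by these compounds alone, this is the first reading of a single change at this position: in this assay, methylcarbamoyl in place of hydrogen on this aromatic carbon gives a 1.5-fold lower number from compound 1 to compound 3 (0.17 log units; within the scatter) and so produces no shift that can be told from the usual scatter. On the core of compound 1, the aromatic carbon that lies ortho to a fused ring and meta to a fused ring therefore accepts methylcarbamoyl with maximal plasma concentration left within the scatter, and this one substitution does not by itself raise exposure. Nothing at hand bears on why the read-out stays within the scatter with this group in place.

From the compounds shown here alone, whether another group on this aromatic carbon, such as an amine, a nitrile or a hydroxymethyl group, would move the maximal plasma concentration of the core of compound 1 beyond the scatter remains open. Also open, going by these compounds, is whether methylcarbamoyl behaves the same way on a core that differs elsewhere; the present reading rests on this single pair alone.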